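Swapping the Pendant Ring on a Shared Polycyclic Core

A few compounds are considered here, and "the series" means these few. Any claim that something is new, unique, unknown or untested is made for them only; others in the source may bear on it.

Measured compounds:
compound 1, `Cc1nc2c3ccccc3ccc2c2nc3c(ccc4ccccc43)c(-c3cc([N+](=O)[O-])ccc3N)c12`: 110 ug/mL
compound 2, `Cc1nc2c3ccccc3ccc2c2nc3c(ccc4ccccc43)c(-c3cccc([N+](=O)[O-])c3)c12`: 157 ug/mL
compound 3, `Cc1nc2c3ccccc3ccc2c2nc3c(ccc4ccccc43)c(-c3cc(O)nc4ccccc34)c12`: 148 ug/mL

Three compounds share one core and differ only in the aromatic group hanging from it. In a functional assay, with a stated time of 90 s (on this read-out higher numbers stand for weaker inhibition and lower numbers for stronger inhibition), compound 1 gives 110 ug/mL. Its number is the smallest of the three, yet that counts for little, since the steps to compound 2 (a 1.4-fold higher number from compound 1 to compound 2 (0.15 log units; within the scatter)) and to compound 3 (a 1.3-fold higher number from compound 1 to compound 3 (0.13 log units; within the scatter)) both sit within the scatter, as does the step between compound 2 and compound 3 (a 1.1-fold lower number from compound 2 to compound 3 (0.03 log units; within the scatter)).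

Compound 4, `Cc1nc2c3ccccc3ccc2c2nc3c(ccc4ccccc43)c(-c3cccnc3)c12`, has not yet been measured in this assay. It differs from compound 1 in one place: pyridin-3-yl in place of 2-amino-5-nitrophenyl on an aromatic carbon. The measured steps that bear on this change are the removal of the amino group from compound 1 to compound 2 and the exchange of the whole pendant ring from compound 1 to compound 3; neither moved the number beyond the scatter. On that evidence a change of the pendant ring to pyridin-3-yl is expected to produce no step beyond the scatter in this assay, in either direction.

Compound 4 is therefore estimated at 130 ug/mL, with a range from 70 ug/mL to 250 ug/mL. The step this estimate implies, a 1.2-fold higher number from compound 1 to compound 4 (0.07 log units; within the scatter), is expected to stay within the scatter.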

Compound 4, half-maximal inhibitory concentration: 156 ug/mL
Estimate against measurement, compound 4: 1.2-fold (0.08 log units) below, within the range that was stated.
By their numbers in this assay, from the lowest: compounds 1, 3, 4 and 2 (each within the scatter of the next).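

In this assay, this position, opposite the ring nitrogen, takes pyridin-3-yl with its 6 heavy atoms in place of the 10 heavy atoms of 2-amino-5-nitrophenyl, and the step stays within the scatter: a 1.4-fold higher number from compound 1 to compound 4 (0.15 log units; within the scatter). The same holds when pyridin-3-yl is set against the other two pendant groups, with a 1.1-fold higher number from compound 3 to compound 4 (0.02 log units; within the scatter) and a 1.0-fold lower number from compound 2 to compound 4 (0.00 log units; within the scatter), so among these four compounds neither the nitro group nor the amino group is required for a number in this range. Nothing on hand accounts for how little the number moves at this position.

As far as these compounds go, all four pendant groups are aromatic rings, so it remains open whether a non-aromatic group here, such as a piperidine or a carboxylic acid, would move the number beyond the scatter. Also open, from the compounds shown here alone, is how far the shared core alone sets the level of these numbers, which a plain hydrogen or methyl at this position could help to show.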